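Taking a methoxy group off a compound at the limit

A few compounds are considered here, and "the series" means these few. Any claim that something is new, unique, unknown or untested is made for them only; others in the source may bear on it.

In a functional assay on A549 cells (Homo sapiens) for cytotoxicity, read by WST assay, with a stated time of 24 h (a higher number here means a weaker inhibitor, a lower number a stronger inhibitor), compound 3 `COc1ccc2c(C(=O)/C(C#N)=C/c3cn(Cc4ccc(Cl)cc4)c4ccccc34)c[nH]c2c1` gives > 50000 nM, which is a limit of the assay and not a number. Compound 1 `N#C/C(=C\c1cn(Cc2ccc(Cl)cc2)c2ccccc12)C(=O)c1c[nH]c2cc(F)ccc12` gives > 50000 nM, and this too is a limit. Compound 2 `N#C/C(=C\c1c[nH]c2ccccc12)C(=O)c1c[nH]c2ccccc12` is the only one of the three with a true number, 16100 nM. The picture so far is therefore dominated by the limit of > 50000 nM in this assay, at which 2 of the 3 values shown sit.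

Compound 4 `N#C/C(=C\c1cn(Cc2ccc(Cl)cc2)c2ccccc12)C(=O)c1c[nH]c2ccccc12` is reached from compound 3 by a single change, hydrogen in place of methoxy on an aromatic carbon, so that 6-methoxy-1H-indol-3-yl becomes 1H-indol-3-yl. The closest measured evidence is a step that the two limits leave unreadable from compound 1 to compound 3, where methoxy takes the place of fluoro. That step offers no size to carry over, but it does show two different groups on an aromatic carbon, both ending at a limit. No step beyond the scatter is therefore expected in this assay, and no direction can be given. The expected outcome is a number no higher from compound 3 to compound 4 (the limit leaves the size open). A reading that again stops at the limit is the likeliest result. For compound 4 the estimate is 50000 nM, with an expected range from 20000 nM to 100000 nM.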

Compound 4, half-maximal inhibitory concentration: > 50000 nM
Compound 4: only a limit was reported (the forecaster's own chance of this, stated with the estimate: 70%); the middle value lies on the limit itself.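

Compound 4 gives > 50000 nM in this assay, which is a limit of the assay and not a number. For the compounds shown here, the steps that join compounds 1, 3 and 4 cannot be read, so hydrogen now joins fluoro and methoxy as a third group on this aromatic carbon that ends at the same limit: the limit of > 50000 nM in this assay, at which 3 of the 4 values shown sit. Compound 4 also provides the first readable step, an at least 3.1-fold higher number from compound 2 to compound 4 (0.49 log units; beyond the scatter), with 4-chlorobenzyl in place of hydrogen on an aromatic nitrogen, and that step lies beyond the scatter.

Any difference among hydrogen, fluoro and methoxy on this carbon stays open, as the compounds carrying them that also carry 4-chlorobenzyl give no number to compare. On these data alone, how an amine or a carboxylic acid on this aromatic carbon would read is also open, as is whether a methyl group in place of 4-chlorobenzyl on the aromatic nitrogen would give a true number in this assay.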